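The compounds below may be only part of what the source reports. "The series", "measured", "known", "first", "only" and "open" are said of these compounds alone.

Measured so far in a functional assay on HEK293 cells for antagonist activity at transient receptor potential M8 protein (Canis lupus familiaris), read by FLIPR and calcium flux; a lower number here means a stronger inhibitor, a higher number a weaker inhibitor:

Compound 1 `Clc1ccccc1-c1ccc2[nH]c(/C=C/C3CCCCC3)nc2c1`: 8.9 nM
Compound 2 `FC(F)(F)Oc1ccccc1-c1ccc2[nH]c(/C=C/C3CCCC3)nc2c1`: 110 nM
Compound 3 `FC1(F)CCC(/C=C/c2nc3cc(-c4ccccc4C(F)(F)F)ccc3[nH]2)CC1`: 21 nM

Compound 3 holds the second highest of the three numbers in this assay. Its nearest neighbour is compound 1, whose lower number lies beyond the usual scatter, so compound 1 is the stronger inhibitor of the two. The furthest is compound 2, whose higher number also lies beyond the scatter, so compound 2 is the weaker inhibitor. None of these three compounds differs from another in only one place, so no single change among them can be read on its own.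

Compound 4 `FC(F)(F)c1ccccc1-c1ccc2[nH]c(/C=C/C3CCOCC3)nc2c1` has not yet been measured. It differs from compound 3 in one place: oxan-4-yl in place of 4,4-difluorocyclohexyl on a double-bonded chain carbon bound to a double-bonded chain carbon.

Within the data shown here, with no isolated step of this kind among the measured compounds, the expectation rests on the change itself: a carbon-only ring with two fluorines gives way to a smaller ring with one oxygen. Compound 4 is expected to give a somewhat higher number, a step of a 2.1-fold higher number from compound 3 to compound 4 (0.33 log units; beyond the scatter), so a weaker inhibitor than compound 3. The estimate for compound 4 in this assay is 45 nM, with a likely range from 12 nM to 170 nM.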

Compound 4, half-maximal inhibitory concentration: 7.1 nM
Beside the measured number, compound 4's estimate is 6.3-fold (0.80 log units) above it, and the stated range ends above it.
By their numbers in this assay, from the lowest: compounds 4 and 1 (each within the scatter of the next); then compound 3; then compound 2.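

In this assay, putting oxan-4-yl in place of 4,4-difluorocyclohexyl gives a 3.0-fold lower number from compound 3 to compound 4 (0.47 log units; beyond the scatter), a modest step, so compound 4 is the stronger inhibitor of this pair. Among these compounds, this is the first single change that can be read on its own, and it shows that this position, on a double-bonded chain carbon bound to a double-bonded chain carbon, tolerates a ring with a hetero atom and a hydrogen-bond acceptor, with no fluorine needed. No measurement at hand accounts for this gain.

On these data alone, from this single step, it stays open whether the ring oxygen or the loss of the two fluorines matters more. Also open, as far as these compounds go, is how this position would respond to a ring amine such as piperidin-4-yl, or to a carboxylic acid on the ring.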